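Extending but-2-en-1-yl to 3-phenylprop-2-en-1-yl

A few compounds are considered here, and "the series" means these few. Any claim that something is new, unique, unknown or untested is made for them only; others in the source may bear on it.

Going by the values given here, in a functional assay on P388 cells (Mus musculus) for cytotoxicity (on this read-out higher numbers stand for weaker inhibition and lower numbers for stronger inhibition), compound 3 `C/C=C/CN1C(=O)[C@@H](C)NC(=O)[C@@H]2Cc3ccc(OC)c(c3)Oc3ccc(cc3)C[C@@H](C(=O)N2C)N(C)C(=O)[C@H](C)NC(=O)[C@H](Cc2ccc(OC)cc2)N(C)C(=O)[C@@H]1C` gives 9.12 nM, the middle of the three numbers so far. Compound 2 `CCCN1C(=O)[C@@H](C)NC(=O)[C@@H]2Cc3ccc(OC)c(c3)Oc3ccc(cc3)C[C@@H](C(=O)N2C)N(C)C(=O)[C@H](C)NC(=O)[C@H](Cc2ccc(OC)cc2)N(C)C(=O)[C@@H]1C` lies lower at 3.98 nM, and compound 1 `COc1ccc(C[C@H]2C(=O)N[C@@H](C)C(=O)N(C)[C@H]3Cc4ccc(cc4)Oc4cc(ccc4OC)C[C@@H](C(=O)N[C@H](C)C(=O)N[C@@H](CCCCO)C(=O)N2C)N(C)C3=O)cc1` lies higher at 219 nM. Compound 4 `COc1ccc(C[C@H]2C(=O)N[C@@H](C)C(=O)N(C)[C@H]3Cc4ccc(cc4)Oc4cc(ccc4OC)C[C@@H](C(=O)N[C@H](C)C(=O)N(C/C=C/c4ccccc4)[C@@H](C)C(=O)N2C)N(C)C3=O)cc1` has phenyl in place of methyl on a double-bonded chain carbon bound to a double-bonded chain carbon. Among the compounds with values here, one measured step bears on this chain: a 2.3-fold higher number from compound 2 to compound 3 (0.36 log units; beyond the scatter), for prop-1-en-1-yl in place of ethyl. Within the data shown here, no measured compound carries the phenyl, so the guidance is thin. A further modest rise in this assay is expected, with wide uncertainty. The step expected for compound 4 is a 2.2-fold higher number from compound 3 to compound 4 (0.34 log units; beyond the scatter). Compound 4 is estimated at 20 nM, with an expected range of 6 nM to 70 nM.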

Compound 4, half-maximal inhibitory concentration: 10.7 nM
Estimate against measurement, compound 4: 1.9-fold (0.27 log units) above; the range from low to high includes it.
By their numbers in this assay, from the lowest: compound 2; then compounds 3 and 4 (each within the scatter of the next); then compound 1.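

Phenyl in place of methyl on a double-bonded chain carbon bound to a double-bonded chain carbon leaves this assay within the scatter (a 1.2-fold higher number from compound 3 to compound 4 (0.07 log units; within the scatter)), so this position takes one six-membered aromatic ring without a readable change. Against the ethyl end of compound 2, the longer group still stands apart (a 2.7-fold higher number from compound 2 to compound 4 (0.43 log units; beyond the scatter)), a gap of similar size to the one already seen with prop-1-en-1-yl (a 2.3-fold higher number from compound 2 to compound 3 (0.36 log units; beyond the scatter)). Nothing available explains this flat response.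

Still open, on these data alone, is how the position responds to a chain ending in an amine or a carboxylic acid. A longer saturated chain is equally untested here.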